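A few compounds are considered here, and "the series" means these few. Any claim that something is new, unique, unknown or untested is made for them only; others in the source may bear on it.

Compound 1 `O=C(Nc1cccc(F)c1)c1cc(=O)[nH]c2cc(-c3cccc(F)c3)ccc12` is the anchor of this short series: in a functional assay on KYSE-410 cells (Homo sapiens) for antiproliferative activity, read by MTT assay, with a stated time of 72 h (on this read-out lower numbers stand for stronger inhibition and higher numbers for weaker inhibition), compound 1 gives 10900 nM. Compound 2 `Cc1ccc(-c2ccc3c(C(=O)Nc4cccc(F)c4)cc(=O)[nH]c3c2)cc1` carries 4-methylphenyl in place of 3-fluorophenyl on an aromatic carbon. In this assay compound 2 gives > 20000 nM, which is a limit of the assay and not a number, namely (the limit of > 20000 nM in this assay, at which 1 of the 2 values shown sits). Going by the values given here, the one measured step, an at least 1.8-fold higher number from compound 1 to compound 2 (0.26 log units; that floor lies within the scatter), therefore ends at that limit and is not resolved beyond the scatter, so compound 2 stands at the limit rather than at a fixed point. Among the compounds with values here, compound 3 `C=Cc1ccc2c(C(=O)Nc3cccc(F)c3)cc(=O)[nH]c2c1` takes the change (vinyl in place of 4-methylphenyl on an aromatic carbon), a truncation that no measured step covers; the only movement on record, an at least 1.8-fold higher number from compound 1 to compound 2 (0.26 log units; that floor lies within the scatter), concerns a different exchange and gives no direction for this one. For compound 3 the expected reading is 15000 nM, within a range from 4000 nM to 60000 nM. The step this implies, an at least 1.3-fold lower number from compound 2 to compound 3 (0.12 log units; that floor lies within the scatter), is an estimate only, and a limit may again be all that is reported.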

Compound 3, half-maximal inhibitory concentration: 13600 nM
Estimate against measurement, compound 3: 1.1-fold (0.04 log units) above; measured number inside the range.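

In this assay the record (a 1.2-fold higher number from compound 1 to compound 3 (0.10 log units; within the scatter)) does not separate vinyl from 3-fluorophenyl on this aromatic carbon, so a six-membered aromatic ring of carbon only at this position is not needed for a reading of this size. Vinyl in place of 4-methylphenyl (an at least 1.4-fold lower number from compound 2 to compound 3 (0.16 log units; that floor lies within the scatter)) is likewise not resolved. Compound 2 therefore remains a limit and not a number: the limit of > 20000 nM in this assay, at which 1 of the 3 values shown sits.

Open, on these data alone, is whether an amine, a carboxylic acid or a longer alkyl chain at this position would move the number beyond the scatter. Also open, as far as these compounds go, is whether a plain hydrogen there would read any differently from vinyl, and whether any change elsewhere on the shared core would do more than a change at this position.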